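The source may hold more compounds than are shown below. What is called first, only, known or untested is meant among the compounds shown, and "the series" means these compounds.

Compound 1 `O=C(Nc1ccc(Sc2nc3ccccc3s2)c(Cl)c1)c1ccccc1O`: > 100000 nM, a limit of the assay
Compound 2 `COc1c(Br)cc(Br)cc1C(=O)Nc1ccccc1`: > 100000 nM, a limit of the assay
Compound 3 `COc1c(Br)cc(Br)cc1C(=O)Nc1ccc(Sc2nc3ccccc3s2)cc1`: > 100000 nM, a limit of the assay

In an assay for inhibition of HSP60/HSP10 (Homo sapiens), with a stated time of 60 min (on this read-out higher numbers stand for weaker inhibition and lower numbers for stronger inhibition), compound 2 gives > 100000 nM, which is a limit of the assay and not a number. Compound 2 therefore stands where all three measured compounds stand, at the limit of > 100000 nM in this assay, at which 3 of the 3 values shown sit. Compound 4 `COc1c(Br)cccc1C(=O)Nc1ccccc1` differs from compound 2 in one place: hydrogen in place of bromo on an aromatic carbon. For the measured compounds named here, no step between measured compounds is available to calibrate this change, so no shift beyond the usual scatter is expected in this assay. Compound 4 is estimated to give 150000 nM, with an expected range from 50000 nM to 500000 nM. The expected step that the limit leaves unreadable from compound 2 to compound 4 is accordingly estimated to be small, most likely ending again at the limit.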

Compound 4, half-maximal inhibitory concentration: > 100000 nM
Compound 4 ended at the assay's limit; the forecaster's own chance of this, stated with the estimate: 85%; the middle value does not contradict the limit.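

Compound 2 and compound 4 both end at a limit in this assay, so the step between them cannot be read. The compounds shown leave open what structure would give a value short of that limit.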